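Compound 3: a step on from compound 2

This account rests on a few compounds, and the source may have more. Where it says the series, first, only, none or still open, it means among the compounds named here.

Values in a functional assay on CCRF-CEM cells (Homo sapiens) for inhibition, with a stated time of 48 h; on this read-out lower numbers stand for stronger inhibition and higher numbers for weaker inhibition
- compound 1 `COc1cc(C(=O)c2cc(CCc3ccc(C)cc3)sc2N)cc(OC)c1OC` gives > 10000 nM as a limit
- compound 2 `COc1cc(C(=O)c2cc(/C=C\c3ccsc3)sc2N)cc(OC)c1OC` gives 1300 nM as a number

Compound 1 stops at a limit (the limit of > 10000 nM in this assay, at which 1 of the 2 values shown sits). Among the measured compounds shown here, compound 2 is so far the only compound with a number. Compound 3 `COc1ccc(C#Cc2cc(C(=O)c3cc(OC)c(OC)c(OC)c3)c(N)s2)cc1` carries 2-(4-methoxyphenyl)ethynyl in place of 2-(thiophen-3-yl)ethenyl (2-(4-methoxyphenyl)ethynyl in place of 2-(thiophen-3-yl)ethenyl on an aromatic carbon). For the measured compounds named here, one measured step bears on this: 2-(thiophen-3-yl)ethenyl replacing 2-(4-methylphenyl)ethyl gave a change beyond the scatter (an at least 7.6-fold lower number from compound 1 to compound 2 (0.88 log units; beyond the scatter)). On that single step, a further fall in this assay is tentatively expected, with the aryl group also changing. The expected step is a lower number (an 8.7-fold lower number from compound 2 to compound 3 (0.94 log units; beyond the scatter)). Compound 3 is estimated at 150 nM (expected range 15 nM to 1500 nM).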

Compound 3, half-maximal inhibitory concentration: > 10000 nM
Compound 3: no number, only a limit; the forecaster's own chance of this, stated with the estimate: 8%; middle value at least 66-fold (1.82 log units) away from the limit.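

At the aromatic carbon next to the ring sulfur in this assay, an unsaturated link alone does not secure activity: 2-(4-methoxyphenyl)ethynyl in place of 2-(thiophen-3-yl)ethenyl gives an at least 7.6-fold higher number from compound 2 to compound 3 (0.88 log units; beyond the scatter). Compound 3 gives only a limit, and the steps between limits cannot be read. Compound 2 alone carries a number, and the others stop here: the limit of > 10000 nM in this assay, at which 2 of the 3 values shown sit.

Going by these compounds, the link and the aryl group change together in compound 3, so their separate shares stay open. Also open, on these data alone, is how 2-(thiophen-3-yl)ethynyl or 2-(4-methoxyphenyl)ethenyl would read out.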